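Prenyl to cyclopentyl on the shared core

A few compounds are considered here, and "the series" means these few. Any claim that something is new, unique, unknown or untested is made for them only; others in the source may bear on it.

Measured in a functional assay (trachea) with Cavia porcellus as the target; on this read-out higher numbers stand for weaker inhibition and lower numbers for stronger inhibition:
compound 1 `CCn1nc(-c2cccnc2)c2ccccc2c1=O` gives 1320 nM
compound 2 `CCCCCCCCn1nc(-c2cccnc2)c2ccccc2c1=O` gives 21900 nM
compound 3 `CC(C)=CCn1nc(-c2cccnc2)c2ccccc2c1=O` gives 1380 nM

Compound 3 stands level with compound 1 (a 1.0-fold higher number from compound 1 to compound 3 (0.02 log units; within the scatter)), and both lie well apart from compound 2 (a 16-fold lower number from compound 2 to compound 3 (1.20 log units; beyond the scatter)). From the compounds shown here alone, the next structure is compound 4 `O=c1c2ccccc2c(-c2cccnc2)nn1C1CCCC1` with cyclopentyl in place of 3-methylbut-2-en-1-yl on an aromatic nitrogen and its value in this assay is still open. Among the compounds with values here, no measured compound carries one five-membered non-aromatic ring of carbon only at this place, so no measured step covers the change directly.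

Two kinds of step bear on it. Swapping the chain of compound 1 for that of compound 3 moved the number by no more than the scatter (a 1.0-fold higher number from compound 1 to compound 3 (0.02 log units; within the scatter)). Only the long chain of compound 2 gave large steps (a 17-fold higher number from compound 1 to compound 2 (1.22 log units; beyond the scatter) and a 16-fold lower number from compound 2 to compound 3 (1.20 log units; beyond the scatter)). Cyclopentyl is far closer to the groups of compound 1 and compound 3 than to that long chain, so a large step is not expected here. The expected step (a 1.1-fold higher number from compound 3 to compound 4 (0.04 log units; within the scatter)) is small, with no clear direction. The untested ring keeps the range wide. Estimated value for compound 4: 1500 nM (expected range 500 nM to 5000 nM).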

Compound 4, half-maximal inhibitory concentration: 2750 nM
Beside the measured number, compound 4's estimate is 1.8-fold (0.26 log units) below it; measured number inside the range.
By their numbers in this assay, from the lowest: compounds 1, 3 and 4 (each within the scatter of the next, the first and the last beyond it); then compound 2.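

In this assay, closing the five carbons of 3-methylbut-2-en-1-yl into cyclopentyl, the only ring at this position among the compounds shown, gives a 2.0-fold higher number from compound 3 to compound 4 (0.30 log units; within the scatter), so this exchange of an open chain with one double bond for a ring of the same atoms is not resolved from the scatter. Against the ethyl group, however, the same ring gives a 2.1-fold higher number from compound 1 to compound 4 (0.32 log units; beyond the scatter), the first separation beyond the scatter among the short groups on this aromatic nitrogen, since compound 1 and compound 3 could not be told apart. Cyclopentyl still falls well short of the long-chain result, with an 8.0-fold lower number from compound 2 to compound 4 (0.90 log units; beyond the scatter), which leaves octyl as the group furthest from the others in this set.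

No measurement shown gives a cause for these steps.

From the compounds shown here alone, whether cyclopropyl, cyclohexyl or a chain ending in an amine or a carboxylic acid would stay with the short groups remains open, as does the chain length between ethyl and octyl at which the large step sets in.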